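Extending the hydrazone chain of a nitrophenyl thiazole

A few compounds are considered here, and "the series" means these few. Any claim that something is new, unique, unknown or untested is made for them only; others in the source may bear on it.

Measured compounds:
compound 1, `CC(C)=NNc1nc(-c2cccc([N+](=O)[O-])c2)cs1`, 1070 nM
compound 2, `CCCCC/C(CC)=N\Nc1nc(-c2cccc([N+](=O)[O-])c2)cs1`, 7150 nM
compound 3, `CCCC/C(CC)=N\Nc1nc(-c2cccc([N+](=O)[O-])c2)cs1`, 6030 nM

In an assay on isolated protein for inhibition of Amine oxidase [flavin-containing] A (Homo sapiens), read by fluorescence, with a stated time of 20 min (on this read-out lower numbers stand for stronger inhibition and higher numbers for weaker inhibition), compound 1 gives the lowest number of the three, 1070 nM. Compound 2 gives 7150 nM and compound 3 gives 6030 nM, both well beyond the scatter from compound 1. Between them, the step of a 1.2-fold lower number from compound 2 to compound 3 (0.07 log units; within the scatter) is small and lies within the scatter, so shortening the chain by one carbon on a saturated chain carbon, four bonds along the chain from a carbon with a double bond to nitrogen, left the number essentially unchanged.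

Compound 4, `CCCCCC/C(C)=N\Nc1nc(-c2cccc([N+](=O)[O-])c2)cs1`, has not yet been measured in this assay. It differs from compound 1 by pentyl in place of hydrogen on a saturated chain carbon bound to a carbon with a double bond to nitrogen. Among the compounds with values here, no measured pair reproduces this exact change, but compounds 2 and 3, which both carry longer chains on the hydrazone carbon than compound 1, give higher numbers than compound 1 in this assay. The step from compound 2 to compound 3 suggests that the precise chain length matters little once the chain is long.

On this basis compound 4 is expected to give a higher number than compound 1, a step of about a 4.2-fold higher number from compound 1 to compound 4 (0.62 log units; beyond the scatter). The estimate for compound 4 in this assay is 4500 nM, with a range from 1500 nM to 13000 nM.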

Compound 4, half-maximal inhibitory concentration: 10900 nM
For compound 4 the middle estimate is 2.4-fold (0.38 log units) below the measured one; low and high end bracket the measured number.
By their numbers in this assay, from the lowest: compound 1; then compounds 3, 2 and 4 (each within the scatter of the next).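

In this assay, the change of pentyl in place of hydrogen on a saturated chain carbon bound to a carbon with a double bond to nitrogen can now be read directly, and it gives a 10-fold higher number from compound 1 to compound 4 (1.01 log units; beyond the scatter), a large step. Within the data shown here, until now, the earlier compounds offered only one step within the hydrazone chain, a 1.2-fold lower number from compound 2 to compound 3 (0.07 log units; within the scatter), which lies within the scatter; the new step shows that this position is not indifferent to change, since adding the pentyl chain to compound 1 weakens inhibition well beyond the scatter. Nothing measured here explains why the number rises with this change.

The compounds shown leave open how the number moves with chains of intermediate size at this position, since a single step from hydrogen to pentyl cannot show whether it climbs gradually or rises abruptly, as a propyl chain might help to reveal. They also leave open whether a chain of similar size carrying an amine, a hydroxyl group or a carboxylic acid, or a phenyl ring in place of pentyl, would give a number nearer that of compound 1.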